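Cinnamyl in place of carbamoylmethyl on a purine nucleoside

The compounds below may be only part of what the source reports. "The series", "measured", "known", "first", "only" and "open" are said of these compounds alone.

Compound 1 `C=CCn1c(=S)n([C@@H]2O[C@H](CO)[C@H]3OC(C)(C)O[C@H]32)c2nc(N)nc(O)c21`: 89%
Compound 2 `NC(=O)Cn1c(=O)n(C2OC(CO)[C@@H](O)[C@H]2O)c2nc(N)nc(O)c21`: 32%

In a functional assay on the whole organism (B cells) with Mus musculus as the target (a higher number here means a larger maximal response, a lower number a smaller maximal response), compound 2 gives the lower of the two numbers, and compound 1 stands well above it, beyond the scatter. Compound 3 `Nc1nc(O)c2c(n1)n(C1OC(CO)[C@@H](O)[C@H]1O)c(=O)n2C/C=C/c1ccccc1` has not yet been measured; it differs from compound 2 by 2-phenylethenyl in place of carbamoyl on a saturated chain carbon bound to an aromatic nitrogen. Among the compounds with values here, no step between two measured compounds isolates this change, so the forecast rests on the two values alone. Since compound 1, which carries a plain allyl chain rather than a carbamoylmethyl group, reaches 89%, a rise a number 33 percentage points higher from compound 2 to compound 3 (beyond the scatter) is expected, beyond the scatter. For compound 3 the expected maximal response is 65%, within 40% to 90%.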

Compound 3, largest response reached (reported as maximal response), in percent of the reference or control that the assay uses: 73%
Compound 3: middle estimate off by 8 percentage points, on the low side, and the stated range covers the measured number.
By their numbers in this assay, from the lowest: compound 2; then compound 3; then compound 1.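

In this assay, 2-phenylethenyl in place of carbamoyl on a saturated chain carbon bound to an aromatic nitrogen gives a number 41 percentage points higher from compound 2 to compound 3 (beyond the scatter). Within the data shown here, this is the first comparison in which only this one place changes, and it shows that the response depends on the group carried here. Nothing measured here gives a reason for the rise. The compounds shown leave open whether the phenyl ring or the chain's double bond matters, which a saturated 3-phenylpropyl chain could help separate. On these data alone, how a chain ending in an amine or a carboxylic acid would behave also remains open.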